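The compounds below may be only part of what the source reports. "The series", "measured", "known", "first", "only" and "open" are said of these compounds alone.

Compound 3 `CC(=O)O[C@@H]1OC(=O)[C@](OC(C)=O)(C(C)=O)[C@@H]1C` stands, together with compound 2 `CC(=O)O[C@@H]1OC(=O)[C@@](C(C)=O)(C2SCCCS2)[C@@H]1C`, at the ceiling of the values shown. In a functional assay on MCF7 cells (Homo sapiens) for cytotoxicity, read by MTT assay (on this read-out higher numbers stand for weaker inhibition and lower numbers for stronger inhibition), compound 3 gives > 50000 nM, which is a limit of the assay and not a number. Compound 2 likewise gives only a limit in this assay, > 50000 nM. Compound 1 `CC(=O)CC[C@]1(C(C)=O)C(=O)O[C@@H](OC(C)=O)[C@H]1C` alone gives a number in this assay, 6000 nM, from which the steps of an at least 8.3-fold higher number from compound 1 to compound 2 (0.92 log units; beyond the scatter) and an at least 8.3-fold higher number from compound 1 to compound 3 (0.92 log units; beyond the scatter) run upward, while the step that the two limits leave unreadable from compound 2 to compound 3 cannot be read (the limit of > 50000 nM in this assay, at which 2 of the 3 values shown sit). Compound 4 `CC(=O)O[C@@H]1OC(=O)[C@](OC(=O)c2ccccc2)(C(C)=O)[C@@H]1C` differs from compound 3 by phenyl in place of methyl on a carbonyl carbon. Among the compounds with values here, no measured step touches this carbonyl carbon, so none bears on the change, and compound 4 is expected to remain near the limit, a step of a number no higher from compound 3 to compound 4 (the limit leaves the size open) not expected to go beyond the scatter. Compound 4 is therefore estimated at 50000 nM, between 15000 nM and 200000 nM.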

Compound 4, half-maximal inhibitory concentration: 22000 nM
The estimate for compound 4 lay 2.3-fold (0.36 log units) above the measured number; measured number inside the range.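

In this assay, within the data shown here, phenyl in place of methyl on this carbonyl carbon gives an at least 2.2-fold lower number from compound 3 to compound 4 (0.35 log units; beyond the scatter), so a change at this position, which no earlier step touched, does register in the read-out. Compound 4 thus comes off the ceiling and gives a number, whereas compound 2 and compound 3 give only limits. How large the step really is stays open: the limit of > 50000 nM in this assay, at which 2 of the 4 values shown sit.

The compounds shown leave open how a longer alkyl chain, a pyridine ring or a phenyl ring bearing an amine on this carbonyl carbon would read. They also leave open whether a benzyl group would behave like phenyl.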